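The compounds below may be only part of what the source reports. "The series", "measured", "known", "first", "only" and "open" are said of these compounds alone.

Three compounds of this series have been run in a functional assay on HCT-116 cells (Homo sapiens) for inhibition, read by MTT assay, with a stated time of 2 days, tested at 10 uM; a lower number here means less inhibition, a higher number more inhibition at the concentration tested (going by the name of the read-out). Compound 1 `COc1ccc(-c2cn(-c3ccc(O)c(C(=O)Nc4cccc(C(F)(F)F)c4)c3)nn2)cc1` gives 9%, compound 2 `COc1cc(OC)cc(-c2cn(-c3ccc(O)c(C(=O)OCCCc4ccccc4)c3)nn2)c1` gives 19%, and compound 3 `COC(=O)c1cc(-n2cc(-c3cccc(O)c3)nn2)ccc1O` gives 6%. Compound 3 carries the lowest of the three numbers; its gap to compound 1 lies within the scatter, while compound 2 stands beyond the scatter above it. No two of these measured compounds differ in a single place, so no step size is fixed from them. Compound 4 `COC(=O)c1cc(-n2cc(-c3cc(O)ccc3O)nn2)ccc1O` differs from compound 3 by hydroxy in place of hydrogen on an aromatic carbon. With nothing to anchor it, the expected step in this assay is small, in either direction or none beyond the scatter, put here at a number 4 percentage points higher from compound 3 to compound 4 (within the scatter). Compound 4 is therefore estimated at 10%, with a range from 0% to 25%.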

Compound 4, a percentage reported as inhibition, at one concentration (the size of the read-out at that concentration, not a potency): 15%
Compound 4: the middle estimate sits 5 percentage points below what was measured; the range from low to high includes it.
By their numbers in this assay, from the lowest: compounds 3, 1, 4 and 2 (each within the scatter of the next, the first and the last beyond it).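

In this assay, for the compounds shown here, hydroxy in place of hydrogen on an aromatic carbon gives a number 9 percentage points higher from compound 3 to compound 4 (within the scatter), the first single-place step. At this site, ortho to a large group and para to a hydroxy group, the added hydroxy therefore produces no change beyond the scatter. No available data explain the step. Still open, from the compounds shown here alone, is whether an amine or a fluorine at the same site would shift the number beyond the scatter. Also open, going by these compounds, is whether a carboxylic acid in place of the methyl ester would do so.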